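Piperazine amide series: isoxazole carbonyl in place of acetylbutyl

The source may hold more compounds than are shown below. What is called first, only, known or untested is meant among the compounds shown, and "the series" means these compounds.

Of the compounds shown here, two have been measured in an assay on isolated protein for inhibition of calcium/calmodulin-dependent protein kinase type IV (Homo sapiens), read by HTRF, tested at 10 uM; on this read-out lower numbers stand for less inhibition and higher numbers for more inhibition at the one concentration tested (going by the name of the read-out). Compound 1 `CN(CCCn1ccnc1)C(=O)[C@@H]1CCCN1c1nccc(Nc2ccccc2)n1` gives 0% in this assay. Compound 2 `CC(=O)CCCCC(=O)N1CCN(c2nccc(Oc3cccc(C)c3)n2)CC1` gives 0% in this assay and stands level with compound 1 at the digits printed, within the scatter of repeated measurements. Among the measured compounds shown here, no pair of measured compounds differing in one place is available, so no measured step can be drawn on.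

Compound 3 `Cc1cccc(Oc2ccnc(N3CCN(C(=O)c4c(C)noc4C)CC3)n2)c1` is not yet measured. For the measured compounds named here, its single difference from compound 2 is 3,5-dimethyl-1,2-oxazol-4-yl in place of 4-acetylbutyl on a carbonyl carbon. The change sits on the carbonyl carbon whose other neighbours are an amide-type nitrogen in a ring; cut one bond further out it reads (4-acetylbutyl)carbonyl to (3,5-dimethyl-1,2-oxazol-4-yl)carbonyl.

Since compound 2 gives 0% in this assay, the expected step is no change at the digits printed from compound 2 to compound 3 (within the scatter), none beyond the scatter. Compound 3 is estimated at 0%, with a range from -5% to 10%.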

Compound 3, a percentage reported as inhibition, at one concentration (the size of the read-out at that concentration, not a potency): 0%
The estimate for compound 3 equals the measured number at the digits printed; low and high end bracket the measured number.
By their numbers in this assay, from the lowest: compounds 1, 2 and 3 (each within the scatter of the next).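

In this assay, replacing 4-acetylbutyl with 3,5-dimethyl-1,2-oxazol-4-yl on the carbonyl carbon gives no change at the digits printed from compound 2 to compound 3 (within the scatter). Among the compounds shown here, this is the first one-place comparison: at this position, an open chain with no ring and a five-membered aromatic ring with 2 hetero atoms are not told apart by this read-out, but with compound 2 at 0% and compound 3 at 0%, neither end of the step shows any inhibition that the change could have altered. No measurement on hand bears on this result.

Going by these compounds, whether any group on this carbonyl carbon can raise the read-out remains open; a primary amine, a carboxylic acid or a longer chain would test this. The effect of changes elsewhere on the shared core is equally unsettled.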